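Ethyl for methyl on the core: a second look

This account rests on a few compounds, and the source may have more. Where it says the series, first, only, none or still open, it means among the compounds named here.

Measured so far:
compound 1 `Cc1nn(C)c2c1C(c1ccccc1Cl)=NCCN2C` — 2.5 mg/kg
compound 2 `CCn1nc(C)c2c1N(C)CCN=C2c1ccccc1Cl` — 5 mg/kg
compound 3 `Cc1nn(C)c2c1C(c1cccc(Br)c1)=NCCN2` — 0.63 mg/kg

All three were run in a functional assay on the whole organism for positive allosteric modulation, with Rattus norvegicus as the target; on this read-out higher numbers stand for an effect only at larger amounts of compound and lower numbers for an effect already at smaller amounts. Compound 1 gives 2.5 mg/kg, compound 2 gives 5 mg/kg, and compound 3 gives 0.63 mg/kg, the lowest of the three, with its steps to both others beyond the scatter.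

The change from compound 1 to compound 2 is methyl in place of hydrogen on a saturated chain carbon bound to an aromatic nitrogen. The step it made was a 2.0-fold higher number from compound 1 to compound 2 (0.30 log units; within the scatter), so the two numbers cannot be ordered against each other.

Compound 4 `CCc1nn(C)c2c1C(c1cccc(Br)c1)=NCCN2` has not yet been measured in this assay. It differs from compound 3 by methyl in place of hydrogen on a saturated chain carbon bound to an aromatic carbon. This is the same kind of change as from compound 1 to compound 2, but not the same: there the place was on a saturated chain carbon bound to an aromatic nitrogen, here it is on a saturated chain carbon bound to an aromatic carbon. The difference between the core of compound 3 and the core of compound 1 is not broken down here.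

Going by the values given here, with only one precedent, the step from compound 3 to compound 4 is expected to be about a 1.6-fold higher number from compound 3 to compound 4 (0.20 log units; within the scatter), a step of similar size to the one from compound 1 to compound 2 because of a 2.0-fold higher number from compound 1 to compound 2 (0.30 log units; within the scatter). On that basis compound 4 is estimated at 1 mg/kg, with a range from 0.4 mg/kg to 2.5 mg/kg.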

Compound 4, minimum effective dose: 1.25 mg/kg
Beside the measured number, compound 4's estimate is 1.3-fold (0.10 log units) below it, within the range that was stated.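

In this assay, the new step is a 2.0-fold higher number from compound 3 to compound 4 (0.30 log units; within the scatter), so these two numbers cannot be ordered against each other, and ethyl in place of methyl on the core of compound 3 gives no readable gain or loss. Set beside the earlier step, methyl in place of hydrogen reads alike on the two cores: the same change on two cores in this assay, a 2.0-fold higher number (0.30 log units; within the scatter) from compound 1 to compound 2 and a 2.0-fold higher number (0.30 log units; within the scatter) from compound 3 to compound 4, 1.0-fold (0.00 log units) apart, within the scatter of two such steps

Going by these compounds alone, this agreement shows only that the change stayed within the scatter on both cores; it does not establish a fixed step that can be carried to other cores, as it rests on two pairs, the two cores differ in more than one place, and the change sits on a saturated chain carbon bound to an aromatic nitrogen in one pair and on a saturated chain carbon bound to an aromatic carbon in the other.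

The compounds shown leave open whether a longer chain such as propyl, or a different group such as an amine or a carboxylic acid, at either place would give a step beyond the scatter. They also leave open how methyl in place of hydrogen reads at each place on the other core, as each place appears here on one core only.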